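Compound 2 to compound 4: one further methoxy

This account rests on a few compounds, and the source may have more. Where it says the series, first, only, none or still open, it means among the compounds named here.

- compound 1 (`O=[N+]([O-])c1ccc(-c2nc3ccccc3[nH]2)c([N+](=O)[O-])c1`) gives > 100000 nM as a limit
- compound 2 (`COc1ccc(-c2nc3cc(C(F)(F)F)ccc3[nH]2)c(OC)c1`) gives > 100000 nM as a limit
- compound 3 (`COc1cc(OC)cc(-c2nc3cc(C(F)(F)F)ccc3[nH]2)c1`) gives > 100000 nM as a limit

In an ADME assay on Vero cells (Chlorocebus sabaeus) for cytotoxicity (a higher number here means that more compound is tolerated, a lower number that less compound is tolerated), compound 2 stands at > 100000 nM as a limit and not a number. For the measured compounds named here, the set so far shows the limit of > 100000 nM in this assay, at which 3 of the 3 values shown sit, and offers no measured step between compounds that differ in one place.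

Compound 4 (`COc1ccc(-c2nc3cc(C(F)(F)F)ccc3[nH]2)c(OC)c1OC`) has methoxy in place of hydrogen on an aromatic carbon of compound 2, ortho to two methoxy groups (methoxy in place of hydrogen on an aromatic carbon) and meta to a large group.

Going by the values given here, with no measured step to size this change, none beyond the usual scatter is expected in this assay and no direction is anticipated. This expectation rests on compound 2 with its limit of > 100000 nM as the only starting point. The expected step (a number no higher from compound 2 to compound 4 (the limit leaves the size open)) is an estimate only. For compound 4 the estimated value is 100000 nM with an expected range of 50000 nM to 200000 nM in this read-out, and a report as a limit is likely.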

Compound 4, half-maximal cytotoxic concentration: 70000 nM
Compound 4: middle estimate off by 1.4-fold (0.15 log units), on the high side, within the range that was stated.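

In this assay, methoxy in place of hydrogen on this aromatic carbon, ortho to two methoxy groups and meta to a large group, gives an at least 1.4-fold lower number from compound 2 to compound 4 (0.15 log units; that floor lies within the scatter). Compound 4 is the only compound shown whose value is a number and not a limit, which gives the series its first reading inside the range of this assay. The true size of the change stays unknown because compound 2 has only a limit, and the step may lie within the scatter or well beyond it: the limit of > 100000 nM in this assay, at which 3 of the 4 values shown sit.

A single step cannot show whether the outcome of this change depends on the two neighbouring methoxy groups named above or holds without them. On these data alone, how a hydroxyl, an amine or a carboxylic acid on this carbon would read in this assay also stays open.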